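Shortening the chain on a weak adenosine receptor blocker

The compounds below may be only part of what the source reports. "The series", "measured", "known", "first", "only" and "open" are said of these compounds alone.

Four close relatives of one core are compared in a functional assay on CHO cells for antagonist activity at adenosine receptor A2b (Homo sapiens), read by 33P incorporation, with a stated time of 20 min; a lower number here means a stronger inhibitor, a higher number a weaker inhibitor. Compound 2 `CCCn1c(-c2ccccc2)nc2c(NC3CCC3)ncnc21` gives 774 nM. Compound 1 `CCn1c(-c2ccccc2)nc2c(NC3CCC3)ncnc21` gives 1440 nM. The change between them is hydrogen in place of methyl on a saturated chain carbon, two bonds along the chain from an aromatic nitrogen, and it made a 1.9-fold higher number from compound 2 to compound 1 (0.27 log units; within the scatter). Compound 3 `CCn1c(-c2ccccc2)nc2c(NC3CCOC3)ncnc21` gives 11500 nM. Its step from compound 1 is an 8.0-fold higher number from compound 1 to compound 3 (0.90 log units; beyond the scatter); the difference between the cores of compound 2 and compound 3 is not broken down here. Compound 4 `Cn1c(-c2ccccc2)nc2c(NC3CCOC3)ncnc21` has not been measured in this assay. It differs from compound 3 by hydrogen in place of methyl on a saturated chain carbon bound to an aromatic nitrogen. This is the same kind of change as between compound 2 and compound 1, but not the same: there the place was two bonds along the chain from an aromatic nitrogen, here the carbon is bound to the aromatic nitrogen. The earlier step was small, so a comparable step is expected, since compound 2 to compound 1 gave a 1.9-fold higher number from compound 2 to compound 1 (0.27 log units; within the scatter). For compound 4 the expected step is a 1.7-fold higher number from compound 3 to compound 4 (0.24 log units; within the scatter). Compound 4 is estimated at 20000 nM, expected between 7000 nM and 55000 nM.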

Compound 4, inhibition constant: 13300 nM
Beside the measured number, compound 4's estimate is 1.5-fold (0.18 log units) above it, and the stated range covers the measured number.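

In this assay, putting methyl where compound 3 carries ethyl gives a 1.2-fold higher number from compound 3 to compound 4 (0.06 log units; within the scatter), so this step is too small to separate the two compounds. Set beside the earlier step on the core with cyclobutyl, it shows that shortening the chain has a similarly small result on both cores, with no measurable difference between the two steps: the same change on two cores in this assay, a 1.9-fold higher number (0.27 log units; within the scatter) from compound 2 to compound 1 and a 1.2-fold higher number (0.06 log units; within the scatter) from compound 3 to compound 4, 1.6-fold (0.21 log units) apart, within the scatter of two such steps

Among these compounds, this does not establish a rule for the series, since it rests on only two pairs, the carbon that changes sits at a different place in each, and neither step rises beyond the scatter, so their agreement shows only that both are small.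

The compounds shown leave open whether a longer chain, such as butyl, on the aromatic nitrogen would shift the number beyond the scatter. They also leave open how a chain ending in an amine or a carboxylic acid would read on either core.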